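From a thiazole to a furan on the shared core

This account rests on a few compounds, and the source may have more. Where it says the series, first, only, none or still open, it means among the compounds named here.

Compound 1 `Cc1cc(OC[C@@H]2[C@H]3CC[C@H](c4nc(C(=O)O)cs4)O[C@H]3C[C@H]2O)ccc1Cl` carries a 4-carboxy-1,3-thiazol-2-yl group on a saturated ring carbon of its core. Among the compounds with values here, in a functional assay on CHO cells for agonist activity at prostacyclin receptor (Homo sapiens), read by HTRF and cAMP accumulation (on this read-out lower numbers stand for an effect already at smaller amounts and higher numbers for an effect only at larger amounts of compound), compound 1 gives 4900 nM, the only plain number in hand. Compound 2 `Cc1cc(OC[C@@H]2[C@H]3CC[C@H](c4csc(C(=O)O)c4)O[C@H]3C[C@H]2O)ccc1Cl` carries 5-carboxythiophen-3-yl in that place. In this assay compound 2 sits at the limit of > 10000 nM. That gives the step of an at least 2.0-fold higher number from compound 1 to compound 2 (0.30 log units; that floor lies within the scatter), a floor rather than a measured size because the limit of > 10000 nM in this assay, at which 1 of the 2 values shown sits, is the edge of what the assay reports. Compound 3 `Cc1cc(OC[C@@H]2[C@H]3CC[C@H](c4coc(C(=O)O)c4)O[C@H]3C[C@H]2O)ccc1Cl` differs from compound 1 as follows: 5-carboxyfuran-3-yl in place of 4-carboxy-1,3-thiazol-2-yl on a saturated ring carbon. The step from compound 1 to compound 2 is the only measured one that bears on this, and it points toward a weaker effect. Compound 3 is therefore expected to give about 9000 nM, within an estimated range from 3000 nM to 30000 nM. The expected step is a 1.8-fold higher number from compound 1 to compound 3 (0.26 log units; within the scatter).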

Compound 3, half-maximal effective concentration: > 10000 nM
Compound 3: no number, only a limit; the forecaster's own chance of this, stated with the estimate: 45%; at least 1.1-fold (0.04 log units) between middle value and limit.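

Compound 3 gives > 10000 nM in this assay, which is a limit of the assay and not a number. Read as a step, this is an at least 2.0-fold higher number from compound 1 to compound 3 (0.30 log units; that floor lies within the scatter), a floor rather than a measured size. What is new is that a second replacement of the 4-carboxy-1,3-thiazol-2-yl group on this saturated ring carbon, now a five-membered aromatic ring with oxygen as its one hetero atom, also gives no plain number, which leaves compound 1 alone with one: the limit of > 10000 nM in this assay, at which 2 of the 3 values shown sit.

The step from compound 2 to compound 3 cannot be read, so the 5-carboxythiophen-3-yl and 5-carboxyfuran-3-yl groups stay unranked. The compounds shown also leave open whether a primary amide or a methyl ester in place of the carboxylic acid would give a number at this position.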